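The compounds below may be only part of what the source reports. "The series", "measured", "known", "first", "only" and "open" are said of these compounds alone.

Compound 1 `CC(=O)OC[C@H]1O[C@H](O[C@]2(COC(C)=O)O[C@H](CO)[C@@H](O)[C@@H]2OC(=O)/C=C/c2ccc(O)cc2)[C@H](O)[C@@H](OC(C)=O)[C@@H]1O`: 1440 nM
Compound 2 `CC(=O)OC[C@H]1O[C@H](O[C@]2(COC(C)=O)O[C@H](CO)[C@@H](O)[C@@H]2OC(=O)/C=C/c2ccc(O)cc2)[C@H](OC(C)=O)[C@@H](O)[C@@H]1O`: 3440 nM

In a functional assay on MCF7 cells (Homo sapiens) for cytotoxicity, read by MTT assay, with a stated time of 2 days (a higher number here means a weaker inhibitor, a lower number a stronger inhibitor), compound 2 has the higher of the two numbers at 3440 nM, so it is the weaker inhibitor. Its gap to compound 1 at 1440 nM lies beyond the usual scatter of repeat measurements. Compound 3 `CC(=O)OC[C@H]1O[C@H](O[C@]2(COC(C)=O)O[C@H](CO)[C@@H](O)[C@@H]2OC(=O)/C=C/c2ccc(O)c(O)c2)[C@H](OC(C)=O)[C@@H](O)[C@@H]1O` changes compound 2 by hydroxy in place of hydrogen on an aromatic carbon, turning 4-hydroxyphenyl into 3,4-dihydroxyphenyl. Going by the values given here, no measured pair shows this change, so only a cautious guess is possible. The expected change is small, toward a lower number and probably within the scatter: a 1.6-fold lower number from compound 2 to compound 3 (0.19 log units; within the scatter). For compound 3 the estimated value is 2200 nM, with an expected range of 800 nM to 6000 nM.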

Compound 3, half-maximal inhibitory concentration: 770 nM
The estimate for compound 3 lay 2.9-fold (0.46 log units) above the measured number; measured number outside the range, below it.
By their numbers in this assay, from the lowest: compounds 3 and 1 (each within the scatter of the next); then compound 2.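

In this assay, hydroxy in place of hydrogen on the aromatic carbon, which turns 4-hydroxyphenyl into 3,4-dihydroxyphenyl, gives a 4.5-fold lower number from compound 2 to compound 3 (0.65 log units; beyond the scatter) and so makes compound 3 the stronger inhibitor. Going by these compounds alone, this is the first sign that this ring position, ortho to a hydroxy group, affects cytotoxicity, and the step lies beyond the scatter. Nothing available explains the step.

Going by these compounds, whether a methoxy group, a fluorine atom or an amine at this position would act like hydroxy stays open. So does whether the same change would have a similar effect on compound 1.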